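A few compounds are considered here, and "the series" means these few. Any claim that something is new, unique, unknown or untested is made for them only; others in the source may bear on it.

Compound 1 `[O-][n+]1nc(NCCn2cccc2)[n+]([O-])c2ccccc21` gives 61000000 nM in a physicochemical assay for solubility, in the presence of a further agent that is not named here (a lower number here means a less soluble compound, a higher number a more soluble compound), the higher of the two numbers recorded so far. Compound 2 `CC1CCCC(C)N1CCNc1n[n+]([O-])c2ccccc2[n+]1[O-]` gives 48000000 nM in this assay, and the two values lie within the scatter of each other, so no order between them is claimed. Compound 3 `CCCN(CCC)CCNc1n[n+]([O-])c2ccccc2[n+]1[O-]` carries dipropylamino in place of 1H-pyrrol-1-yl on a saturated chain carbon, two bonds along the chain from a nitrogen on an aromatic ring. Among the compounds with values here, no measured pair shows this change, and the two recorded values give no ground for a shift in either direction. Compound 3 is therefore expected to sit near compound 1, at 55000000 nM, with a plausible range from 20000000 nM to 130000000 nM. The expected step of a 1.1-fold lower number from compound 1 to compound 3 (0.04 log units; within the scatter) is none beyond the scatter.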

Compound 3, solubility: > 25000000 nM
Compound 3 gave a limit, no number (the forecaster's own chance of this, stated with the estimate: 5%); the middle value is on the limit's open side.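

Within the data shown here, compound 3 gives only the limit > 25000000 nM in this assay and not a number, so no step from compound 1 to compound 3 can be read. The compounds shown leave open where compound 3 stands relative to compound 1.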